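The source may report more compounds than this note shows. Statements on the series, on what has been measured and on what is new or still open speak of the compounds shown alone.

Within the data shown here, compound 3, `OC[C@]1(c2ccccc2)NC[C@H](O)[C@H]1O`, carries a phenyl group on the shared core and gives 630 nM in an assay on isolated protein for inhibition of lysosomal alpha-glucosidase (Homo sapiens) (on this read-out higher numbers stand for weaker inhibition and lower numbers for stronger inhibition), the lowest of the three numbers measured so far. Among the measured compounds shown here, compound 1, `CCCCCCCCC[C@]1(CO)NC[C@@H](O)[C@@H]1O`, bears a nonyl chain in the same position and gives 130000 nM in this assay; no single-point step connects it to compound 3, so the two values only show that the chain-bearing compound sits far higher. Compound 2, `OC[C@]1(c2cccc(F)c2)NC[C@H](O)[C@H]1O`, keeps the aromatic ring but adds a fluoro to it and gives 491000 nM in this assay. For the measured compounds named here, the one step measured on that ring is a 780-fold lower number from compound 2 to compound 3 (2.89 log units; beyond the scatter), a large movement from a single aromatic substituent.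

Compound 4, `OC[C@]1(c2ccc(O)cc2)NC[C@H](O)[C@H]1O`, differs from compound 3 by hydroxy in place of hydrogen on an aromatic carbon. That step bears on it only indirectly: it concerns a different group, and the hydroxy enters at another place on the ring, so its size is not a measure of what a hydroxy will do. Given that the one ring substituent measured so far hurt inhibition sharply in compound 2, compound 4 is expected to lose some ground, with a step of a 2.4-fold higher number from compound 3 to compound 4 (0.38 log units; beyond the scatter). The estimate for compound 4 in this assay is 1500 nM, with a range from 300 nM to 8000 nM.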

Compound 4, half-maximal inhibitory concentration: 376000 nM
Compound 4: the middle estimate sits 250-fold (2.40 log units) below what was measured, outside the stated range (above it).
By their numbers in this assay, from the lowest: compound 3; then compound 1; then compounds 4 and 2 (each within the scatter of the next).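

In this assay, the change from hydrogen to hydroxy on an aromatic carbon, para to a group of 9 heavy atoms, gives a 600-fold higher number from compound 3 to compound 4 (2.78 log units; beyond the scatter) in the sentence's own right as a large loss, so the sharp effect of a ring substituent is no longer confined to the fluoro of compound 2. Together with a 780-fold lower number from compound 2 to compound 3 (2.89 log units; beyond the scatter) as the earlier step, it makes the unsubstituted phenyl of compound 3 the only aromatic compound shown with a low number, while compound 2 and compound 4 stand within the scatter of each other, and no substituted ring shown goes against this. Nothing given here accounts for the size of either step.

Since fluoro and hydroxy differ in both group and place, the compounds shown do not tell whether the ring carbon, the substituent or simply any substitution of the phenyl governs the loss. Going by these compounds, it also remains open whether a smaller change on that same carbon, such as a methyl or an amine, or a hydroxy on another ring carbon, would keep the number of compound 3 at 630 nM or lose as much.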